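Amide variation on a cathepsin S carbamate series

The source may hold more compounds than are shown below. What is called first, only, known or untested is meant among the compounds shown, and "the series" means these compounds.

Compound 3 `C[C@@H](CN1CC(C)(C)c2cc(F)ccc21)NC(=O)O[C@@H](CC1CCCCC1)C(=O)N1CCC1` gives 217 nM in an assay on isolated protein for inhibition of cathepsin S (Homo sapiens); a higher number here means a weaker inhibitor, a lower number a stronger inhibitor. Among the three measured compounds it stands second highest; compound 2 `C[C@@H](CN1CC(C)(C)c2cc(F)ccc21)NC(=O)O[C@@H](CC1CCCCC1)C(=O)N(C)C` gives 227 nM, a number that lies within the scatter of the value of compound 3, while compound 1 `O=C(N[C@@H](COCc1ccccc1)CN1CCc2cc(F)ccc21)O[C@@H](CC1CCCCC1)C(=O)N1CCOCC1`, which differs in several places, lies far lower at 8 nM. Compound 4 `C[C@@H](CN1CC(C)(C)c2cc(F)ccc21)NC(=O)O[C@@H](CC1CCCCC1)C(=O)N1CCN(S(C)(=O)=O)CC1` differs from compound 3 in one place: 4-(methylsulfonyl)piperazin-1-yl in place of azetidin-1-yl on a carbonyl carbon. Going by the values given here, only one measured step bears on this position: a 1.0-fold lower number from compound 2 to compound 3 (0.02 log units; within the scatter). Among the compounds with values here, that step was flat, and no one-place step to a six-membered amide exists here. He therefore expects compound 4 to show little change beyond the scatter, with a step of a 1.1-fold lower number from compound 3 to compound 4 (0.04 log units; within the scatter), and estimates compound 4 at 200 nM, with a range from 70 nM to 600 nM.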

Compound 4, inhibition constant: 1080 nM
For compound 4 the middle estimate is 5.4-fold (0.73 log units) below the measured one, outside the stated range (above it).
By their numbers in this assay, from the lowest: compound 1; then compounds 3 and 2 (each within the scatter of the next); then compound 4.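

The position is not as flat as the first step suggested: azetidin-1-yl and dimethylamino on the carbonyl carbon could not be told apart, but 4-(methylsulfonyl)piperazin-1-yl gives a 5.0-fold higher number from compound 3 to compound 4 (0.70 log units; beyond the scatter) and a 4.8-fold higher number from compound 2 to compound 4 (0.68 log units; beyond the scatter) in this assay on the same core. Nothing available explains this loss of binding.

The compounds shown leave open whether the higher number goes with the six-membered ring or with the methylsulfonyl group. A piperidin-1-yl or an unsubstituted piperazin-1-yl group on the same carbonyl carbon would separate the two.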